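Cytotoxicity of compound 4 after a bromo-for-piperidinyl swap

A few compounds are considered here, and "the series" means these few. Any claim that something is new, unique, unknown or untested is made for them only; others in the source may bear on it.

Measured so far:
compound 1, `CC(C)(C)c1ccc(C(=O)/C=C/c2ccc([N+](=O)[O-])o2)cc1`: > 50000 nM
compound 2, `CSc1ccc(C(=O)/C=C/c2ccc([N+](=O)[O-])o2)cc1`: 13100 nM
compound 3, `O=C(/C=C/c1ccc([N+](=O)[O-])o1)c1ccc(N2CCCCC2)cc1`: > 50000 nM

Compound 3 sits at a limit: in an ADME assay on THP-1 cells (Homo sapiens) for cytotoxicity, read by resazurin assay, with a stated time of 72 h (a lower number here means that less compound is tolerated, a higher number that more compound is tolerated), compound 3 gives > 50000 nM, which is a limit of the assay and not a number. Compound 1 also sits at a limit, giving > 50000 nM in this assay. Compound 2 is the only one of the three with a real number, 13100 nM in this assay. Two of the three values therefore share one position, (the limit of > 50000 nM in this assay, at which 2 of the 3 values shown sit). The steps among them show that changing the group on the aromatic carbon moves tolerance noticeably: an at least 3.8-fold lower number from compound 1 to compound 2 (0.58 log units; beyond the scatter) and an at least 3.8-fold higher number from compound 2 to compound 3 (0.58 log units; beyond the scatter), while a step that the two limits leave unreadable from compound 1 to compound 3.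

Compound 4, `O=C(/C=C/c1ccc([N+](=O)[O-])o1)c1ccc(Br)cc1`, differs from compound 3 in one place: bromo in place of piperidin-1-yl on an aromatic carbon. Because compound 3 is known only as a limit, the step from compound 3 cannot be read directly, and bromo resembles neither of the groups already tested. The two readable steps were each at least modest, so compound 4 is expected to fall somewhere between the number of compound 2 and the limit, as a step of an at least 2.0-fold lower number from compound 3 to compound 4 (0.30 log units; that floor lies within the scatter). The estimate for compound 4 in this assay is 25000 nM, with a range from 8000 nM to 60000 nM.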

Compound 4, half-maximal cytotoxic concentration: 13400 nM
For compound 4 the middle estimate is 1.9-fold (0.27 log units) above the measured one; measured number inside the range.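

In this assay, bromo in place of methylsulfanyl on this aromatic carbon gives a 1.0-fold higher number from compound 2 to compound 4 (0.01 log units; within the scatter), so these two groups cannot be told apart here and compound 2 no longer stands alone with a real number. Bromo in place of piperidin-1-yl gives an at least 3.7-fold lower number from compound 3 to compound 4 (0.57 log units; beyond the scatter), and bromo in place of tert-butyl gives an at least 3.7-fold lower number from compound 1 to compound 4 (0.57 log units; beyond the scatter), which shows that a single bromine atom at this place, para to a large group, is enough to separate compound 4 from both of those compounds. Each of these two steps is only a floor, and the four compounds now fall into two sets, since compound 1 and compound 3 are known only by a limit of the assay: the limit of > 50000 nM in this assay, at which 2 of the 4 values shown sit.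

The compounds shown leave open how far compound 1 and compound 3 actually lie from compound 2 and compound 4, and what separates the two sets. They also leave open where a methoxy group, a carboxylic acid or a primary amine at this aromatic carbon would fall, and whether any of these would stand clearly apart from compound 2 and compound 4.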